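The source may report more compounds than this note shows. Statements on the series, on what has been measured and on what is new or still open speak of the compounds shown alone.

Measured so far:
compound 1, `Nc1ccc(NC(=O)c2c(O)c3cccnc3n(-c3ccccc3)c2=O)cc1`: -5.5%
compound 2, `O=C(Nc1nccs1)c1c(O)c2cccnc2n(-c2ccccc2)c1=O`: 4.6%

In a functional assay on the whole organism for inhibition, with Rattus norvegicus as the target, read by paw edema, at a dose of 100 mg/kg by the oral route (a higher number here means more inhibition at the dose given (going by the name of the read-out), a lower number less inhibition), compound 2 gives the higher of the two numbers, compound 1 standing below it by a number 10.1 percentage points higher from compound 1 to compound 2 (beyond the scatter). Compound 3, `O=C(Nc1ccc(Cl)nc1)c1c(O)c2cccnc2n(-c2ccccc2)c1=O`, differs from compound 2 by 6-chloropyridin-3-yl in place of 1,3-thiazol-2-yl on an amide-type nitrogen. For the measured compounds named here, the only measured step, a number 10.1 percentage points higher from compound 1 to compound 2 (beyond the scatter), swapped one amide substituent for another and was modest; no step exchanges one heteroaryl amide substituent for a second. The expected step of a number 1.6 percentage points lower from compound 2 to compound 3 (within the scatter) is therefore not beyond the scatter in either direction. Compound 3 is estimated in this assay at 3%, range -10% to 16%.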

Compound 3, a percentage reported as inhibition, in the whole organism at one dose (the size of the read-out at that dose, not a potency): 9.2%
Estimate against measurement, compound 3: 6.2 percentage points below; the measured number falls inside the stated range.
By their numbers in this assay, from the lowest: compound 1; then compounds 2 and 3 (each within the scatter of the next).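

In this assay, replacing one heteroaryl group on the amide-type nitrogen with another gives a number 4.6 percentage points higher from compound 2 to compound 3 (within the scatter) and so does not separate 1,3-thiazol-2-yl from 6-chloropyridin-3-yl. Both stand above 4-aminophenyl, the second such replacement at this position to clear the scatter, with 6-chloropyridin-3-yl giving a number 14.7 percentage points higher from compound 1 to compound 3 (beyond the scatter) and still only a modest step. No evidence in hand accounts for these steps.

Open, on these data alone, is whether a longer alkyl chain or a carboxylic acid on the amide-type nitrogen would move the number further. Also open, as far as these compounds go, is whether a methoxy group in place of the chlorine of 6-chloropyridin-3-yl would change it.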